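From 4-nitrophenyl to 2-hydroxyphenyl on a shared core

This account rests on a few compounds, and the source may have more. Where it says the series, first, only, none or still open, it means among the compounds named here.

compound 1 `CC(=O)N1N=C(c2ccc3ccccc3c2)OC1c1ccccc1F` gives 3.36 ug/mL
compound 2 `CC(=O)N1N=C(c2ccc3ccccc3c2)OC1c1ccc(F)cc1` gives 1.82 ug/mL
compound 3 `CC(=O)N1N=C(c2ccc3ccccc3c2)OC1c1ccc([N+](=O)[O-])cc1` gives 8.1 ug/mL

In a functional assay on HepG2 cells (Homo sapiens) for antiproliferative activity, read by MTT assay, with a stated time of 48 h (on this read-out lower numbers stand for stronger inhibition and higher numbers for weaker inhibition), compound 3 has the highest number of the three, which makes it the weakest inhibitor so far. Compound 4 `CC(=O)N1N=C(c2ccc3ccccc3c2)OC1c1ccccc1O` carries 2-hydroxyphenyl in place of 4-nitrophenyl on a saturated ring carbon in the same core. For the measured compounds named here, no measured compound carries 2-hydroxyphenyl, so the guides are indirect. The steps of a 2.4-fold higher number from compound 1 to compound 3 (0.38 log units; beyond the scatter) and a 4.5-fold higher number from compound 2 to compound 3 (0.65 log units; beyond the scatter) are modest and beyond the scatter, whereas a 1.8-fold lower number from compound 1 to compound 2 (0.27 log units; within the scatter) stays within it. Losing 4-nitrophenyl should therefore bring a modest drop in this assay and no more. The expected size is a 2.0-fold lower number from compound 3 to compound 4 (0.31 log units; beyond the scatter) on this estimate. Compound 4 is estimated at 4 ug/mL with an expected range from 1.5 ug/mL to 10 ug/mL for the coming measurement.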

Compound 4, half-maximal inhibitory concentration: 1.84 ug/mL
Compound 4: middle estimate off by 2.2-fold (0.34 log units), on the high side; measured number inside the range.
By their numbers in this assay, from the lowest: compounds 2, 4 and 1 (each within the scatter of the next); then compound 3.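

In this assay, for the compounds shown here, 2-hydroxyphenyl on this saturated ring carbon gives a 4.4-fold lower number from compound 3 to compound 4 (0.64 log units; beyond the scatter) and so leaves 4-nitrophenyl as the only group here that stands apart. Hydroxy in place of fluoro gives a 1.8-fold lower number from compound 1 to compound 4 (0.26 log units; within the scatter) and 2-hydroxyphenyl in place of 4-fluorophenyl gives a 1.0-fold higher number from compound 2 to compound 4 (0.00 log units; within the scatter) and both steps stay within the scatter, so this position accepts a hydroxy group as readily as a fluoro group. No measurement here explains why compound 3 differs. Going by these compounds, whether an amine or a carboxylic acid on this phenyl ring would match compound 4 or compound 3 remains open.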